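The source may report more compounds than this note shows. Statements on the series, on what has been measured and on what is new or still open speak of the compounds shown alone.

In a functional assay on MGC-803 cells (Homo sapiens) for inhibition, read by MTT assay, with a stated time of 72 h (a lower number here means a stronger inhibitor, a higher number a weaker inhibitor), compound 3 `O=C(CSc1nc(Nc2ccccc2)c2ccccc2n1)Nc1ccc(C(F)(F)F)cc1` gives 8670 nM, the lowest of the two numbers shown. Its nearest neighbour is compound 1 `O=C(CSc1nc(Nc2ccccc2)c2ccccc2n1)Nc1cccc(Br)c1`, which gives 9620 nM, and the step of a 1.1-fold lower number from compound 1 to compound 3 (0.05 log units; within the scatter) stays within the scatter. Compound 2 `O=C(CSc1nc(Nc2ccccc2)c2ccccc2n1)Nc1ccc(F)cc1` reaches only the limit > 50000 nM in this assay, a limit and not a number (the limit of > 50000 nM in this assay, at which 1 of the 3 values shown sits). The step to compound 4 `CCc1ccc(NC(=O)CSc2nc(Nc3ccccc3)c3ccccc3n2)cc1` is ethyl in place of trifluoromethyl on an aromatic carbon. For the measured compounds named here, the one measured step at this same aromatic carbon, an at least 5.7-fold lower number from compound 2 to compound 3 (0.76 log units; beyond the scatter), was beyond the scatter, whereas the change of ring position, a 1.1-fold lower number from compound 1 to compound 3 (0.05 log units; within the scatter), was not. Ethyl is a neutral hydrocarbon group of two carbons, and no comparable swap has been measured here, so a small step is expected in this assay. Compound 4 is therefore expected to give 12000 nM, between 4000 nM and 40000 nM, a step of a 1.4-fold higher number from compound 3 to compound 4 (0.14 log units; within the scatter) expected to lie within the scatter.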

Compound 4, half-maximal inhibitory concentration: > 50000 nM
Compound 4 gave a limit, no number; the forecaster's own chance of this, stated with the estimate: 20%; middle value at least 4.1-fold (0.61 log units) away from the limit.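

In this assay, ethyl in place of trifluoromethyl on this aromatic carbon gives an at least 5.7-fold higher number from compound 3 to compound 4 (0.76 log units; beyond the scatter), and 4-ethylphenyl in place of 3-bromophenyl gives an at least 5.1-fold higher number from compound 1 to compound 4 (0.71 log units; beyond the scatter), so the group here matters even when it is not a halogen-bearing one. Compound 4 gives a limit and not a number, the same limit as compound 2: the limit of > 50000 nM in this assay, at which 2 of the 4 values shown sit. The step between these two cannot be read, so ethyl and fluoro cannot be ordered.

As far as these compounds go, whether an amine or a carboxylic acid on this aromatic carbon would give a number remains open. So does whether a longer chain would stay at the limit.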